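Piperidinyl Chain in Place of Hydroxy on a Shared Core

This account rests on a few compounds, and the source may have more. Where it says the series, first, only, none or still open, it means among the compounds named here.

Compound 3 `Cn1cc(C2=C(c3nn(CCCO)c4ncccc34)C(=O)NC2=O)c2ccccc21` gives 85800 nM in a functional assay on K562 cells (Homo sapiens) for antiproliferative activity, read by MTT assay, with a stated time of 48 h; on this read-out higher numbers stand for weaker inhibition and lower numbers for stronger inhibition. Compound 2 `CN(C)CCCn1nc(C2=C(c3cn(C)c4ccccc34)C(=O)NC2=O)c2cccnc21` gives 50400 nM in this assay, and the two are separated by a 1.7-fold higher number from compound 2 to compound 3 (0.23 log units; within the scatter). Compound 1 `Cn1cc(C2=C(c3n[nH]c4ncccc34)C(=O)NC2=O)c2ccccc21` is reported only as a limit, > 100000 nM; it sits at the limit of > 100000 nM in this assay, at which 1 of the 3 values shown sits. Compound 4 `Cn1cc(C2=C(c3nn(CCCN4CCCCC4)c4ncccc34)C(=O)NC2=O)c2ccccc21` differs from compound 3 by piperidin-1-yl in place of hydroxy on a saturated chain carbon, three bonds along the chain from an aromatic nitrogen. Among the measured compounds shown here, the one measured step that bears on this, an amine exchanged for a hydroxy at the same chain position, is a 1.7-fold higher number from compound 2 to compound 3 (0.23 log units; within the scatter), which stayed within the scatter. For compound 4 the expected step in this assay is therefore a 2.1-fold lower number from compound 3 to compound 4 (0.33 log units; beyond the scatter), no larger than the scatter. Compound 4 is estimated at 40000 nM, between 15000 nM and 100000 nM.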

Compound 4, half-maximal inhibitory concentration: 5960 nM
Compound 4: the middle estimate sits 6.7-fold (0.83 log units) above what was measured, and the stated range ends above it.
By their numbers in this assay, from the lowest: compound 4; then compounds 2 and 3 (each within the scatter of the next). At a limit, above all of these: compound 1.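

In this assay, among the compounds shown here, the 3-(piperidin-1-yl)propyl chain gives a 14-fold lower number from compound 3 to compound 4 (1.16 log units; beyond the scatter), a step beyond the scatter, which the earlier steps at this nitrogen chain did not reach. An amine alone does not account for this, as the piperidine ring also gives an 8.5-fold lower number from compound 2 to compound 4 (0.93 log units; beyond the scatter), while the dimethylamino and hydroxy chains stayed within the scatter of each other. Compound 1 is held only at a limit, so an at least 16-fold lower number from compound 1 to compound 4 (1.22 log units; beyond the scatter) is a floor, and nothing measured here explains the gain.

Going by these compounds, whether a morpholin-4-yl or pyrrolidin-1-yl ring would do the same remains open. So does the effect of a longer chain carrying the piperidine.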